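This account rests on a few compounds, and the source may have more. Where it says the series, first, only, none or still open, it means among the compounds named here.

The measured compounds and their values in a physicochemical assay for lipophilicity, at pH 7.4; on this read-out higher numbers stand for higher lipophilicity and lower numbers for lower lipophilicity:

Compound 1, `CCCCCCCc1c(C)nc2cc(OC)ccc2c1O`, gives 3.69.
Compound 2, `CCCCCCCc1c(C)nc2ccccc2c1O`, gives 3.39.
Compound 3, `Cc1[nH]c2ccccc2c(=O)c1Br`, gives 1.67.

Compound 1 and compound 2 share a core and differ in one place: methoxy in place of hydrogen on an aromatic carbon. The step in this assay is a number 0.30 log units higher from compound 2 to compound 1 (within the scatter). Compound 3 stands lowest of the three in this assay; the difference between its core and the core of compound 2 is not broken down here, and the two values simply show that compound 3 sits far below compound 2.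

Compound 4, `COc1ccc2[nH]c(C)c(Br)c(=O)c2c1`, has not yet been measured. It differs from compound 3 by methoxy in place of hydrogen on an aromatic carbon. This is the same change as that from compound 2 to compound 1, at a place described in the same words. On that basis the step is expected to be a number 0.30 log units higher from compound 3 to compound 4 (within the scatter), matching a number 0.30 log units higher from compound 2 to compound 1 (within the scatter) in size. The value of compound 4 in this assay is therefore estimated at 1.97, with a likely range from 1.6 to 2.35.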

Compound 4, distribution coefficient: 1.62
The estimate for compound 4 lay 0.35 log units above the measured number; low and high end bracket the measured number.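

The new step is a number 0.05 log units lower from compound 3 to compound 4 (within the scatter) in this assay, and the earlier step on the other core is a number 0.30 log units higher from compound 2 to compound 1 (within the scatter), so on neither core does methoxy in place of hydrogen on an aromatic carbon move the number clear of repeat-measurement scatter. The two pairs therefore agree only in this: on both cores the change gives a step too small to read, and neither step can be trusted for its direction or exact size, nor can two pairs make a rule for the whole series. Nothing shown here bears on why the steps read as they do.

From the compounds shown here alone, it remains open whether an amine, a carboxylic acid or a fluorine atom in place of the methoxy would give a step beyond the scatter on either core. Going by these compounds, it is also open whether methoxy on a different aromatic carbon, or on a third core, would behave as it does in these two pairs.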